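The compounds below may be only part of what the source reports. "The series", "measured", "known", "first", "only" and "open" are said of these compounds alone.

In a functional assay on HCT-116 cells (Homo sapiens) for antiproliferative activity, with a stated time of 72 h (on this read-out lower numbers stand for stronger inhibition and higher numbers for weaker inhibition), compound 1 `Nc1ncnn2c([C@@H]3O[C@H](CO)[C@@H](O)[C@H]3O)cc(C#CC3CC3)c12` gives 50 nM. Compound 2 `Nc1ncnn2c([C@@H]3O[C@H](CO)[C@@H](O)[C@H]3O)cc(C#Cc3ccc(F)cc3)c12` gives > 100000 nM, which is a limit of the assay and not a number. Compound 2 therefore stands at the weak end of what is shown, as the limit of > 100000 nM in this assay, at which 1 of the 2 values shown sits, records. Compound 3 `Nc1ncnn2c([C@@H]3O[C@H](CO)[C@@H](O)[C@H]3O)cc(C#Cc3cccs3)c12` carries thiophen-2-yl in place of 4-fluorophenyl on a triple-bonded carbon. Going by the values given here, only one measured step changes this same place, an at least 2000-fold higher number from compound 1 to compound 2 (3.30 log units; beyond the scatter). That step shows that the group here can shift the number greatly, but it replaced cyclopropyl with an aromatic ring, and compound 3 still has an aromatic ring in that place. Only a partial recovery towards lower numbers is therefore expected, and the result may stay at the limit. The expected step is an at least 10-fold lower number from compound 2 to compound 3 (1.00 log units; beyond the scatter). The estimated value for compound 3 is 10000 nM, with an expected range of 300 nM to 100000 nM.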

Compound 3, half-maximal inhibitory concentration: 65500 nM
Beside the measured number, compound 3's estimate is 6.6-fold (0.82 log units) below it; the measured number falls inside the stated range.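

Going from cyclopropyl to thiophen-2-yl on the triple-bonded carbon gives a 1300-fold higher number from compound 1 to compound 3 (3.12 log units; beyond the scatter), so the large loss seen with the 4-fluorophenyl group is not confined to that one ring: it appears with both aromatic rings shown. Exchanging one aromatic ring for the other gives an at least 1.5-fold lower number from compound 2 to compound 3 (0.18 log units; that floor lies within the scatter), so this change shows no recovery that can be told apart from ordinary scatter. From the compounds shown here alone, for compound 2 the figure is a limit of the assay and not a number, so the true size of that gap stays unknown: the limit of > 100000 nM in this assay, at which 1 of the 3 values shown sits.

Cyclopropyl is the only non-aromatic group among these compounds, so it remains open whether low numbers belong to that group alone or extend to other non-aromatic groups. Going by these compounds, how a cyclopentyl ring, a straight butyl chain or a chain ending in an amine would fare at this place is also open.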